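The source may hold more compounds than are shown below. What is called first, only, known or untested is meant among the compounds shown, and "the series" means these compounds.

Of the compounds shown here, two sharing one core have been measured in a functional assay on cells for antagonist activity at C-X-C chemokine receptor type 4 (Homo sapiens), read by fluorescence and calcium flux, with stated times of 25 min and 90 s; a higher number here means a weaker inhibitor, a lower number a stronger inhibitor. Compound 1 `c1ccc2c(c1)CN[C@@H](CN(CCCCN(Cc1ccncc1)Cc1ccncc1)[C@H]1CCCc3cccnc31)C2` gives 832 nM. Compound 2 `c1ccc2c(c1)CN[C@@H](CN(CCCCNCC1CCCCC1)[C@H]1CCCc3cccnc31)C2` gives 158 nM, the lower of the two numbers, and its gap to compound 1 lies beyond the usual scatter. Compound 3 `C(=C/CN(C[C@H]1Cc2ccccc2CN1)[C@H]1CCCc2cccnc21)\CNC1CCOCC1` is not yet measured; it differs from compound 2 by 3-((oxan-4-yl)amino)prop-1-en-1-yl in place of 3-((cyclohexylmethyl)amino)propyl on a saturated chain carbon bound to an amine nitrogen, so the saturated carbon ring gives way to a ring with one hetero atom and the chain gains a double bond. In this assay a step toward a weaker inhibitor, of moderate size and beyond the scatter, is expected: the estimated step is a 2.8-fold higher number from compound 2 to compound 3 (0.45 log units; beyond the scatter). Compound 3 is expected to give about 450 nM, likely between 120 nM and 1700 nM.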

Compound 3, half-maximal inhibitory concentration: 15.5 nM
For compound 3 the middle estimate is 29-fold (1.46 log units) above the measured one; measured number below the stated range.
By their numbers in this assay, from the lowest: compound 3; then compound 2; then compound 1.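

In this assay, replacing 3-((cyclohexylmethyl)amino)propyl with 3-((oxan-4-yl)amino)prop-1-en-1-yl on this saturated chain carbon gives a 10-fold lower number from compound 2 to compound 3 (1.01 log units; beyond the scatter). This shows that the group at this position can still change the number by a large margin, even with the shared core kept the same. No measurement shown here accounts for the gain.

As far as these compounds go, the ring and the double bond changed together, so their separate contributions remain unknown. A saturated propyl chain carrying the same oxan-4-yl amine would separate them, while a piperidine ring would test another ring at this position.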